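The source may report more compounds than this note shows. Statements on the series, on what has been measured and on what is new or still open speak of the compounds shown alone.

Compounds measured:
compound 1, `Nc1nc(O)c2c(Cl)cccc2n1`, 4.66
compound 2, `Nc1nc(N)c2c(CSc3ccc(Cl)cc3)cccc2n1`, 7.7

In an assay for inhibition of Dihydrofolate reductase (Homo sapiens) (a higher number here means a more potent compound, by a factor of ten per unit of this negative logarithm, a lower number a less potent compound), compound 1 stands lowest of the two numbers; the nearest is compound 2, whose value lies higher by a margin beyond the usual scatter. The two differ in more than one place, so nothing more than these two values can be said of their relation. Compound 3, `Cc1cccc2nc(N)nc(O)c12`, has not yet been measured in this assay. It differs from compound 1 in one place: methyl in place of chloro on an aromatic carbon. Going by the values given here, no measured pair shows this change, so no direction beyond the scatter is read into it. The expected step is a number 0.06 log units lower from compound 1 to compound 3 (within the scatter). Compound 3 is thus expected to give about 4.6 in this assay, with a range from 4 to 5.2.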

Compound 3, logarithm of the reciprocal of the active concentration, log(1/C): 4.8
The estimate for compound 3 lay 0.20 log units below the measured number, and the stated range covers the measured number.
By their numbers in this assay, from the lowest: compounds 1 and 3 (each within the scatter of the next); then compound 2.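

In this assay, going by these compounds alone, methyl in place of chloro on an aromatic carbon gives a number 0.14 log units higher from compound 1 to compound 3 (within the scatter), the first step that can be read at a single place. On the core of compound 1, this position therefore takes either of these two groups, each of one heavy atom, with no difference beyond the scatter. Nothing available explains why the two groups give such similar numbers.

Going by these compounds, it remains open whether an amine, a methoxy group or a longer chain on this aromatic carbon would give a number beyond the scatter from those of compound 1 and compound 3. On these data alone, it also remains open whether the same exchange of chloro and methyl would give so small a step on the core of compound 2.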